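This account rests on a few compounds, and the source may have more. Where it says the series, first, only, none or still open, it means among the compounds named here.

Compound 1 `CC(C(=O)NCc1ccc(C(F)(F)F)cc1SC1CCCCC1)c1ccc(NS(C)(=O)=O)c(F)c1` sets the reference point here. In an assay on CHO cells for antagonist activity at transient receptor potential cation channel subfamily V member 1 (Homo sapiens), read by FLIPR (on this read-out higher numbers stand for weaker inhibition and lower numbers for stronger inhibition), compound 1 gives 0.5 nM. Compound 2 `CC(C(=O)NCc1ccc(C(F)(F)F)cc1SCc1ccco1)c1ccc(NS(C)(=O)=O)c(F)c1` keeps the same core and differs from compound 1 only at the group carried on the sulfur, and in this assay compound 2 gives 3.2 nM. The step of a 6.4-fold higher number from compound 1 to compound 2 (0.81 log units; beyond the scatter) therefore shows that exchanging one substituent on the sulfur for another moves the inhibition constant by a modest but real amount while keeping strong inhibition. Compound 3 `CC(C(=O)NCc1ccc(C(F)(F)F)cc1[N+](=O)[O-])c1ccc(NS(C)(=O)=O)c(F)c1` stands apart: where compound 1 and compound 2 carry a thioether, compound 3 carries a nitro group, and in this assay compound 3 is recorded as "not active" (no number reported), so no number is available for it. Compound 4 `CC(C(=O)NCc1ccc(C(F)(F)F)cc1-c1cccnc1)c1ccc(NS(C)(=O)=O)c(F)c1` has not been measured. It differs from compound 3 by pyridin-3-yl in place of nitro on an aromatic carbon. Among the compounds with values here, no measured step covers this exchange; the only measured step, from compound 1 to compound 2, concerns substituents on the sulfur and does not touch this position. Within the data shown here, the data show only that the two thioether compounds inhibit strongly and the nitro compound does not. Compound 4 is therefore expected to return into the measurable range, probably weaker than compound 1, with an estimated inhibition constant of 30 nM and a range from 3 nM to 300 nM.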

Compound 4, inhibition constant: 59.4 nM
Beside the measured number, compound 4's estimate is 2.0-fold (0.30 log units) below it, and the stated range covers the measured number.
By their numbers in this assay, from the lowest: compound 1; then compound 2; then compound 4.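

In this assay, within the data shown here, the position on the aromatic carbon ortho to a large group and meta to a trifluoromethyl group turns out not to need a sulfur for measurable inhibition, since compound 4, with pyridin-3-yl attached there, has a number while compound 3 is recorded without one, and the exchange from nitro to pyridin-3-yl therefore has no step that can be read. The position is also far from indifferent to what it carries: the change is a 19-fold higher number from compound 2 to compound 4 (1.27 log units; beyond the scatter) and a 120-fold higher number from compound 1 to compound 4 (2.07 log units; beyond the scatter), both larger than the step between the two thioethers, a 6.4-fold higher number from compound 1 to compound 2 (0.81 log units; beyond the scatter). Nothing measured here explains these differences.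

The compounds shown leave open whether the loss lies with the missing sulfur or with the pyridin-3-yl group itself, as each of these steps changes both at once. As far as these compounds go, a phenyl ring, a pyridin-4-yl group, or a cyclohexyl group joined through an oxygen or an amine nitrogen instead of sulfur at this position would be needed to separate the two, and how any of them would fare remains unknown.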